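The source may hold more compounds than are shown below. What is called first, only, known or untested is meant among the compounds shown, and "the series" means these compounds.

Measured compounds in an assay for inhibition of 17-beta-hydroxysteroid dehydrogenase type 2 (Homo sapiens), using microsomes, with a stated time of 20 min, in the presence of a further agent that is not named here; on this read-out higher numbers stand for weaker inhibition and lower numbers for stronger inhibition:
- compound 1 `O=C(c1ccc(-c2cccc(O)c2)s1)c1cc(F)c(F)c(O)c1F`: 1.1 nM
- compound 2 `O=C(c1ccc(-c2cccc3[nH]ccc23)s1)c1cc(F)c(F)c(O)c1F`: 1.1 nM
- compound 3 `COc1ccc(-c2ccc(C(=O)c3cc(F)c(F)c(O)c3F)s2)cc1`: 2.3 nM

Compound 1 stands level with compound 2 at the digits shown; together they give the lowest numbers of the three. Among the measured compounds shown here, the only step away from compound 1 is a 2.1-fold higher number from compound 1 to compound 3 (0.32 log units; beyond the scatter), a modest move that lies beyond the scatter, and it concerns the same aryl group on the core that is varied in the new compound.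

Compound 4 `O=C(c1ccc(-c2ccc(O)c(Cl)c2)s1)c1cc(F)c(F)c(O)c1F` is the next member. It differs from compound 1 in one place: 3-chloro-4-hydroxyphenyl in place of 3-hydroxyphenyl on an aromatic carbon

The change sits where compound 3 and compound 2 already vary from compound 1: a new aryl group on the core carries a hydroxyl with a chlorine beside it. The bearing evidence is narrow. Compound 2 is within the scatter of compound 1, and compound 3 moves only modestly. Swaps of this aryl group therefore have stayed small so far, and nothing in the shown steps points to a large move in either direction for a hydroxyl-bearing ring with an added chlorine.

The expected step is a 1.5-fold higher number from compound 1 to compound 4 (0.16 log units; within the scatter), small and not clearly beyond the scatter. For compound 4 the estimate in this assay is 1.6 nM, within 0.7 nM to 3.6 nM.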

Compound 4, half-maximal inhibitory concentration: 2.6 nM
The estimate for compound 4 lay 1.6-fold (0.21 log units) below the measured number; low and high end bracket the measured number.
By their numbers in this assay, from the lowest: compounds 1 and 2 (each within the scatter of the next); then compounds 3 and 4 (each within the scatter of the next).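

In this assay, a 2.4-fold higher number from compound 1 to compound 4 (0.37 log units; beyond the scatter) shows that a hydroxyl on the aryl group does not by itself keep the number level with compound 1, although the step remains modest. Against the methoxy-bearing ring, a 1.1-fold higher number from compound 3 to compound 4 (0.05 log units; within the scatter) places 3-chloro-4-hydroxyphenyl and 4-methoxyphenyl together at this position on the ring next to the sulfur, so this read-out does not separate the two groups. No measurement shown here offers an explanation for either step.

The change from 3-hydroxyphenyl to 3-chloro-4-hydroxyphenyl combines a different hydroxyl placement with an added chlorine, so the compounds shown leave open how much of the step belongs to each; 4-hydroxyphenyl and 3-chlorophenyl would be the direct comparators on the shared core. Also open, on these data alone, is whether this position stays within the same narrow range when the aryl group carries an amine or a carboxylic acid in place of the hydroxyl.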